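Adding a Nitro Group to a Shared Anti-Inflammatory Core

The source may report more compounds than this note shows. Statements on the series, on what has been measured and on what is new or still open speak of the compounds shown alone.

Of the compounds shown here, two built on one core have been tested in a functional assay on the whole organism (strain Wistar albino) for inhibition, with Rattus norvegicus as the target, read by paw edema, with a stated time of 2 h, at a dose of 25 mg/kg by the oral route; a lower number here means less inhibition, a higher number more inhibition at the dose given (going by the name of the read-out). Compound 1 `CSc1nn(-c2ccc([N+](=O)[O-])cc2)c2nc(Nc3ccccc3)n(-c3ccccc3)c(=O)c12` gives 37.7%. Compound 2 `O=c1c2c(Nc3ccccc3)nn(-c3ccccc3)c2nc(Nc2ccccc2)n1-c1ccccc1` gives 43.4%; the gap to compound 1 lies within the scatter, so the two numbers count as level. Compound 3 `O=c1c2c(Nc3ccccc3)nn(-c3ccc([N+](=O)[O-])cc3)c2nc(Nc2ccccc2)n1-c1ccccc1` has not been measured. Against compound 2 the change is nitro in place of hydrogen on an aromatic carbon. For the measured compounds named here, no pair of measured compounds isolates this change: compound 1 and compound 2 differ in two places at once, so their values show only that a nitro-bearing compound and one without land close together. Compound 3 is therefore expected to stay near compound 2. The step this expectation implies, a number 2.4 percentage points lower from compound 2 to compound 3 (within the scatter), is none beyond the usual scatter. For compound 3 the estimated inhibition is 41%, within a range from 30% to 52%.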

Compound 3, a percentage reported as inhibition, in the whole organism at one dose (the size of the read-out at that dose, not a potency): 40.8%
Estimate against measurement, compound 3: 0.2 percentage points above; the range from low to high includes it.
By their numbers in this assay, from the lowest: compounds 1, 3 and 2 (each within the scatter of the next).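

In this assay the change from phenyl to 4-nitrophenyl can now be read on its own, and the step is a number 2.6 percentage points lower from compound 2 to compound 3 (within the scatter) so a nitro group at this spot on the ring, para to a large group, leaves the inhibition level at the dose given. A second single change, anilino in place of methylsulfanyl, can also be read on its own, and its step is a number 3.1 percentage points higher from compound 1 to compound 3 (within the scatter) so that swap also leaves the number level on this core. No measurement at hand speaks to why either swap leaves the number level. Still open, going by these compounds, is whether an amine or a carboxylic acid in place of the nitro group would move the inhibition beyond the scatter. Also open, on these data alone, is whether a longer chain on the sulfur, in place of the methyl of methylsulfanyl, would do so.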